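The source may hold more compounds than are shown below. What is called first, only, known or untested is meant among the compounds shown, and "the series" means these compounds.

Measured so far:
compound 1 `O=c1ccn(CCCCCOc2ccc([N+](=O)[O-])cc2)c(=O)[nH]1`: 20000 nM
compound 2 `O=c1ccn(CCCCOc2ccc(Br)cc2)c(=O)[nH]1`: 100000 nM
compound 3 `Nc1ccc(OCCCCCn2ccc(=O)[nH]c2=O)cc1`: > 100000 nM, which is a limit of the assay rather than a number.

In an ADME assay on HEL cells (Homo sapiens) for cytotoxicity, read by microscopy (on this read-out lower numbers stand for higher toxicity in this test and higher numbers for lower toxicity in this test), compound 1 gives 20000 nM, the lowest of the two numbers on hand. Compound 2 sits at the higher number with 100000 nM, a gap beyond the usual scatter. Compound 3 reaches only the limit of the assay, so no number is known for it.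

The step to compound 4 `Cc1ccc(OCCCCCn2ccc(=O)[nH]c2=O)cc1` changes one group on the shared core of compound 1: methyl in place of nitro on an aromatic carbon. Among the compounds with values here, one measured step bears on this: an at least 5.0-fold higher number from compound 1 to compound 3 (0.69 log units; beyond the scatter), which also removed the nitro group and pushed the number past the reach of the assay. The group entering in compound 4 is a methyl rather than an amino, so that evidence is indirect; still, loss of the nitro group is what the two changes share. A rise in the number is therefore expected for compound 4, though a smaller one than the measured step showed. The step from compound 1 to compound 4 is estimated at a 2.5-fold higher number from compound 1 to compound 4 (0.40 log units; beyond the scatter). Compound 4 is expected to give 50000 nM in this assay, within a range from 20000 nM to 100000 nM.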

Compound 4, minimum cytotoxic concentration: 100000 nM
Beside the measured number, compound 4's estimate is 2.0-fold (0.30 log units) below it; the measured number falls inside the stated range.
By their numbers in this assay, from the lowest: compound 1; then compounds 2 and 4 (each within the scatter of the next).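

In this assay, putting methyl in place of nitro on the aromatic carbon para to a large group gives a 5.0-fold higher number from compound 1 to compound 4 (0.70 log units; beyond the scatter), a modest step that lies beyond the scatter and means lower toxicity in this test. Within the data shown here, until now the only step away from nitro at this position was an at least 5.0-fold higher number from compound 1 to compound 3 (0.69 log units; beyond the scatter), which gave a minimum and left the size open, so this is the first step out of compound 1 with a size that can be read, and both groups placed here, methyl and amino, raise the number. The remaining step is a number no higher from compound 3 to compound 4 (the limit leaves the size open), and its size cannot be read. Compound 3 carries a limit and not a number: the limit of > 100000 nM in this assay, at which 1 of the 4 values shown sits.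

Two replacements cannot tell whether the rise comes from losing the nitro or from the particular group that enters, and a plain hydrogen, a chlorine, a methoxy or a carboxylic acid at the same position would help separate the two. On these data alone, it also remains open whether the same step holds on a shorter or longer chain.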